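The source may hold more compounds than are shown below. What is called first, only, known or untested is meant among the compounds shown, and "the series" means these compounds.

Compound 1, with the structure `COc1ccc(C(=O)/C=C/c2ccc(N(C)C)cc2)c2c1C=CC(C)(C)O2`, was examined in a functional assay on SK-OV-3 cells (Homo sapiens) for antiproliferative activity, read by MTT assay, with a stated time of 24 h (on this read-out higher numbers stand for weaker inhibition and lower numbers for stronger inhibition), where compound 1 gives 2750 nM. Compound 2, `COc1ccc(C(=O)/C=C/c2ccc3ccccc3n2)c2c1C=CC(C)(C)O2`, gives 2350 nM in this assay, a value lying within the scatter of that of compound 1. Compound 3, `COc1ccc(C(=O)/C=C/c2ccc(OC)c(OC)c2OC)c2c1C=CC(C)(C)O2`, returns only a limit in this assay, > 10000 nM. Among the two numbers shown, compound 1 holds the highest, with compound 2 the nearest.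

Compound 4, `COc1ccc(C(=O)/C=C/c2ccc(Cl)cc2)c2c1C=CC(C)(C)O2`, has not yet been measured. It differs from compound 1 in one place: chloro in place of dimethylamino on an aromatic carbon. For the measured compounds named here, no measured pair shows this change, so compound 4 is expected to sit close to compound 1, with a step of a 1.3-fold higher number from compound 1 to compound 4 (0.10 log units; within the scatter) that leans toward a higher number but need not pass the scatter. Compound 4 is estimated at 3500 nM, between 1200 nM and 10000 nM.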

Compound 4, half-maximal inhibitory concentration: > 10000 nM
Compound 4: only a limit was reported; the forecaster's own chance of this, stated with the estimate: 15%; middle value at least 2.8-fold (0.45 log units) away from the limit.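

In this assay, the change from 4-(dimethylamino)phenyl to 4-chlorophenyl gives the first single-place step among these compounds: an at least 3.6-fold higher number from compound 1 to compound 4 (0.56 log units; beyond the scatter). The group on this aromatic carbon, para to a large group, therefore matters on the shared core, and chloro does not stand in for dimethylamino here. The step is open-ended, as compound 4 returns only a limit: the limit of > 10000 nM in this assay, at which 2 of the 4 values shown sit.

The compounds shown leave open whether a smaller amine, such as a primary amine, or a hydroxyl group at this position would keep the number of compound 1. They also leave open whether any other halogen, such as fluoro, would behave like chloro.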